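The source may hold more compounds than are shown below. What is called first, only, known or untested is meant among the compounds shown, and "the series" means these compounds.

In a functional assay on NCI-H2228 cells (Homo sapiens) for inhibition, read by CellTiter-Glo, with a stated time of 96 h (a lower number here means a stronger inhibitor, a higher number a weaker inhibitor), compound 1 (`Cc1cc(Nc2ncc(Cl)c(Nc3cn(C)nc3S(=O)(=O)C(C)C)n2)c(OC2CC2)cc1C(=O)C(C)C`) gives 149 nM, and compound 2 (`Cc1cc(Nc2ncc(Cl)c(Nc3cn(C)nc3S(=O)(=O)C(C)C)n2)c(OC(C)C)cc1C1CNC1`) gives 288 nM. Within the data shown here, these are the only two measurements available, and they lie within the usual scatter of each other, so compound 1 cannot be ranked apart from compound 2.

The next structure is compound 3 (`Cc1cc(Nc2ncc(Cl)c(Nc3cn(C)nc3S(=O)(=O)C(C)C)n2)c(OC2CC2)cc1C1CCCN(C)C1`), which keeps the rest of compound 1 and carries 1-methylpiperidin-3-yl in place of isopropylcarbonyl on an aromatic carbon, ortho to a methyl group: 1-methylpiperidin-3-yl in place of isopropylcarbonyl on an aromatic carbon. Among the measured compounds shown here, no pair of measured compounds differs in one place only, so nothing measured isolates this change. Compound 2 differs from compound 1 in more than one place, yet the value of compound 2, 288 nM, stays within the scatter of the value of compound 1. On that slender evidence, no step beyond the scatter is expected in this assay, and neither direction is favoured with any confidence. The expected change is a 1.1-fold lower number from compound 1 to compound 3 (0.06 log units; within the scatter). For compound 3 the estimated value is 130 nM, with an expected range from 35 nM to 450 nM.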

Compound 3, half-maximal inhibitory concentration: 32 nM
The estimate for compound 3 lay 4.1-fold (0.61 log units) above the measured number; measured number below the stated range.
By their numbers in this assay, from the lowest: compound 3; then compounds 1 and 2 (each within the scatter of the next).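

In this assay this position, on an aromatic carbon ortho to a methyl group, proves sensitive to what it carries: 1-methylpiperidin-3-yl in place of isopropylcarbonyl gives a 4.7-fold lower number from compound 1 to compound 3 (0.67 log units; beyond the scatter) and is the only single-place step shown, which the earlier pair of compounds could not provide. The change removes a chain with no ring and a double bond outside aromatic rings, and brings in a six-membered non-aromatic ring with 1 hetero atom. The counts of hydrogen-bond donors and acceptors are the same on both sides, so the step does not follow a change in those counts, and nothing measured here accounts for it.

One step cannot show whether the ring, its nitrogen or the methyl group on that nitrogen matters most, or whether the attachment point on the ring plays any part. A cyclohexyl group, an unsubstituted piperidin-3-yl group and a 1-methylpiperidin-4-yl group at this position are the kinds of comparison that would separate these possibilities.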